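A Nitro Group Added to the Compound 2 Amide

The source may report more compounds than this note shows. Statements on the series, on what has been measured and on what is new or still open speak of the compounds shown alone.

In a functional assay on KB cells (Homo sapiens) for inhibition, read by MTT assay, with a stated time of 24 h, tested at 100 ug/mL (a lower number here means less inhibition of growth, a higher number more inhibition of growth at the concentration tested), compound 1 (`CC(=O)SCCC(CCCCC(=O)O)SC(C)=O`) gives 8.03%, while compound 2 (`O=C(CCCCC1CCSS1)Nc1cccc(C(F)(F)F)c1`) gives 80%, the higher of the two numbers and beyond the scatter. Compound 3 (`O=C(CCCCC1CCSS1)Nc1ccc([N+](=O)[O-])c(C(F)(F)F)c1`) differs from compound 2 in one place: nitro in place of hydrogen on an aromatic carbon. The nitro takes the place of hydrogen on an aromatic carbon, ortho to a trifluoromethyl group. Going by the values given here, no measured pair shows what this change does, so no step beyond the scatter is expected, and the estimated change is a slight fall, a number 5 percentage points lower from compound 2 to compound 3 (within the scatter). For compound 3 the expected value is 75%, within an estimated range of 50% to 95%.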

Compound 3, percent growth inhibition at one concentration: 49.5%
For compound 3 the middle estimate is 25.5 percentage points above the measured one; the whole stated range lies above it.
By their numbers in this assay, from the lowest: compound 1; then compound 3; then compound 2.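

At this position on the aromatic ring, ortho to a trifluoromethyl group and para to a large group, the ring does not tolerate every change: in this assay, nitro in place of hydrogen gives a number 30.5 percentage points lower from compound 2 to compound 3 (beyond the scatter), a large step. The position therefore bears on growth inhibition at the concentration tested. Nothing shown accounts for this fall.

As far as these compounds go, whether the fall belongs to nitro itself or to any added group here remains open; an amine or a nitrile at this position would help separate the two. Also open, from the compounds shown here alone, is whether nitro gives a similar step on a ring without the trifluoromethyl group.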